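The source may hold more compounds than are shown below. What is called first, only, known or untested is meant among the compounds shown, and "the series" means these compounds.

Compound 1 `CCOC(=O)/C=C/c1cc(O)c(O)cc1-c1cc2ccccc2o1` is tested in a functional assay on Cortical neurone cells (Rattus norvegicus, strain Sprague-Dawley) for cytotoxicity, read by MTT assay, with stated times of 10 days, 2 h and 24 h (on this read-out lower numbers stand for an effect already at smaller amounts and higher numbers for an effect only at larger amounts of compound), where compound 1 gives 46100 nM. Compound 2 `CCOC(=O)/C=C/c1cccc(/C=C/c2cc(O)c(O)c(O)c2)c1` reaches only a limit of the assay in this assay: compound 2 gives > 50000 nM. Among the compounds with values here, of these two values, compound 1 holds the only actual number, since the other sits at a limit (the limit of > 50000 nM in this assay, at which 1 of the 2 values shown sits). Compound 3 `CCOC(=O)/C=C/c1cc(O)c(O)cc1-c1cc2cccc(O)c2o1` differs from compound 1 by hydroxy in place of hydrogen on an aromatic carbon, a hydroxy in place of hydrogen on an aromatic carbon. Within the data shown here, no measured pair shows this change, so the step from compound 1 to compound 3 is expected to stay within the usual scatter, as a 1.2-fold lower number from compound 1 to compound 3 (0.06 log units; within the scatter). Compound 3 is therefore estimated at 40000 nM, between 15000 nM and 100000 nM.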

Compound 3, half-maximal effective concentration: > 50000 nM
Compound 3 ended at the assay's limit (the forecaster's own chance of this, stated with the estimate: 40%); at least 1.2-fold (0.09 log units) between middle value and limit.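

With hydroxy in place of hydrogen on this aromatic carbon, all that can be read in this assay is an at least 1.0-fold higher number from compound 1 to compound 3 (0.03 log units; that floor lies within the scatter), so this change gives no sign of an effect at smaller amounts of compound. As far as these compounds go, the true size of the step stays unknown, since compound 3 sits at a limit of the assay rather than at a number: the limit of > 50000 nM in this assay, at which 2 of the 3 values shown sit. Open, from the compounds shown here alone, is whether an amine or a carboxylic acid on this same carbon would shift the number, and how far above the limit compound 3 lies.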